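Toward compound 4: a hydroxylated, chlorinated group on the amine

This account rests on a few compounds, and the source may have more. Where it says the series, first, only, none or still open, it means among the compounds named here.

Compound 1 `COc1ccc(N/C=C\C(=O)c2ccc(OC)cc2)cc1` gives 100000 nM
Compound 2 `COc1cc(C(=O)/C=C\Nc2ccccc2O)c(Br)c(OC)c1OC` gives 200 nM
Compound 3 `COc1ccccc1N/C=C\C(=O)c1cc(OC)c(OC)c(OC)c1` gives 2500 nM

These three numbers come from a functional assay on K562 cells (Homo sapiens) for cytotoxicity, read by trypan blue exclusion, with a stated time of 96 h (on this read-out lower numbers stand for stronger inhibition and higher numbers for weaker inhibition), and span a wide range. Compound 3 stands second highest among them, with 2500 nM as its value. Its number lies above that of compound 2 and below that of compound 1, and both gaps are beyond the scatter.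

The next compound is compound 4 `COc1cc(C(=O)/C=C\Nc2cc(O)ccc2Cl)cc(OC)c1OC`, which carries 2-chloro-5-hydroxyphenyl in place of 2-methoxyphenyl on an amine nitrogen. For the measured compounds named here, no measured pair isolates this change. Going by the values given here, compound 2, at 200 nM, is the only measured compound with a hydrogen-bond donor in the group on the amine nitrogen, and it gives the lowest number. However, it also differs from compound 3 elsewhere, so this is weak support. A move toward stronger inhibition, beyond the scatter, is therefore expected, and the estimated step is a 6.3-fold lower number from compound 3 to compound 4 (0.80 log units; beyond the scatter) in this assay. Compound 4 is expected at 400 nM (estimated range 60 nM to 2500 nM).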

Compound 4, half-maximal inhibitory concentration: 2500 nM
The estimate for compound 4 lay 6.3-fold (0.80 log units) below the measured number; low and high end bracket the measured number.
By their numbers in this assay, from the lowest: compound 2; then compounds 3 and 4 (each within the scatter of the next); then compound 1.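

In this assay, for the compounds shown here, the change to 2-chloro-5-hydroxyphenyl in place of 2-methoxyphenyl on an amine nitrogen gives no change at the digits printed from compound 3 to compound 4 (within the scatter) and is the first step that isolates a single place. It shows that, for this pair on the shared core, a hydrogen-bond donor can enter the group on the amine nitrogen while the number stays the same. No measured property of either group is available to account for this outcome.

Chlorine and hydroxyl enter together in this step, so the compounds shown leave open what each would do alone and whether their contributions offset each other. They also leave open how a plain phenyl, or a phenyl bearing an amine or a carboxylic acid, would read out on this nitrogen.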